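A few compounds are considered here, and "the series" means these few. Any claim that something is new, unique, unknown or untested is made for them only; others in the source may bear on it.

Compound 2 `O=C(Nc1ccc(Cl)c(-c2nnc3c(Cl)cccn23)c1)c1cccc(Cl)c1` belongs to a small set of three measured analogues built on a shared core. In a functional assay on HeLa cells (Homo sapiens) for antiproliferative activity, read by MTT assay, with a stated time of 72 h (on this read-out lower numbers stand for stronger inhibition and higher numbers for weaker inhibition), compound 1 `Cc1nc(C(=O)Nc2ccc(Cl)c(-c3nnc4c(Cl)cccn34)c2)cs1` gives 79800 nM. Compound 2 in this assay reaches only the limit, > 100000 nM. Compound 3 `CS(=O)(=O)c1ccc(C(=O)Nc2ccc(Cl)c(-c3nnc4c(Cl)cccn34)c2)c(Cl)c1` likewise stops at the limit in this assay, > 100000 nM. Within the data shown here, the single step between measured compounds that differ in one place, an at least 1.2-fold higher number from compound 1 to compound 2 (0.09 log units; that floor lies within the scatter), is a floor that lies within the scatter, so no measured change in this assay has moved the number beyond it.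

Compound 4 `O=C(Nc1ccc(Cl)c(-c2nnc3c(Cl)cccn23)c1)c1c(F)cccc1Cl` differs from compound 2 by 2-chloro-6-fluorophenyl in place of 3-chlorophenyl on a carbonyl carbon. Among the measured compounds shown here, no measured step involves a 2-chloro-6-fluorophenyl on the carbonyl carbon, so the expectation rests on the floor step above and on (the limit of > 100000 nM in this assay, at which 2 of the 3 values shown sit). For compound 4 no shift beyond the scatter in this assay is expected, and the step that the limit leaves unreadable from compound 2 to compound 4 is therefore estimated as essentially flat. Compound 4 is expected to give 150000 nM, between 40000 nM and 600000 nM, most likely again reported only as a limit.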

Compound 4, half-maximal inhibitory concentration: > 100000 nM
Compound 4 gave a limit, no number (the forecaster's own chance of this, stated with the estimate: 70%); the middle value does not contradict the limit.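

In this assay, compound 4 remains at a limit, so a phenyl group on the carbonyl carbon carrying both chlorine and fluorine gives no number here, and the step between compound 2 and compound 4 cannot be read. Among these compounds, the one step that can be read is an at least 1.2-fold higher number from compound 1 to compound 4 (0.09 log units; that floor lies within the scatter), so replacing 2-methyl-1,3-thiazol-4-yl with 2-chloro-6-fluorophenyl on the carbonyl carbon also shows no change beyond the scatter. The limit now covers most of the set, leaving compound 1 as the only compound with a number: the limit of > 100000 nM in this assay, at which 3 of the 4 values shown sit.

Going by these compounds, whether an amine or a carboxylic acid on the ring attached to the carbonyl carbon, or a longer chain in its place, would give a number remains open. The compounds shown also leave open whether any change at this position can shift the read-out beyond the scatter.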